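This account rests on a few compounds, and the source may have more. Where it says the series, first, only, none or still open, it means among the compounds named here.

Measured so far:
compound 1 `CN(CCC(N)=O)C[C@H]1O[C@@H](n2cnc3c(N)ncnc32)[C@H](O)[C@@H]1O` gives 7000 nM;
compound 2 `CN(CCCN)C[C@H]1O[C@@H](n2cnc3c(N)ncnc32)[C@H](O)[C@@H]1O` gives 500000 nM;
compound 3 `CN(CCCCON)C[C@H]1O[C@@H](n2cnc3c(N)ncnc32)[C@H](O)[C@@H]1O` gives 18 nM.

In an assay on isolated protein for inhibition of S-adenosylmethionine decarboxylase proenzyme (Homo sapiens) (on this read-out higher numbers stand for weaker inhibition and lower numbers for stronger inhibition), compound 3 stands lowest of the three, and so is the strongest inhibitor shown: the step of a 390-fold lower number from compound 1 to compound 3 (2.59 log units; beyond the scatter) and the step of a 28000-fold lower number from compound 2 to compound 3 (4.44 log units; beyond the scatter) both lie beyond the scatter. Compound 4 `C[S+](C)C[C@H]1O[C@@H](n2cnc3c(N)ncnc32)[C@H](O)[C@@H]1O` differs from compound 3 by a group of 3 heavy atoms (2 carbon, 1 sulfur; no ring) in place of a group of 8 heavy atoms (5 carbon, 2 nitrogen, 1 oxygen; no ring), on a saturated chain carbon bound to a saturated ring carbon. Going by the values given here, no measured step covers this change directly. What the measured steps do show is that the tail matters greatly: trading the (aminooxy)methyl group for amino gave a 28000-fold lower number from compound 2 to compound 3 (4.44 log units; beyond the scatter) in reverse, and trading it for carbamoyl gave a 390-fold lower number from compound 1 to compound 3 (2.59 log units; beyond the scatter) in reverse. Compound 4 keeps none of these tails, and the group that enters carries a net charge and no hydrogen-bond donor or acceptor. A large rise in this assay is therefore expected for compound 4, estimated as a 5600-fold higher number from compound 3 to compound 4 (3.74 log units; beyond the scatter), giving an expected value of 100000 nM with a range from 5000 nM to 2000000 nM.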

Compound 4, half-maximal inhibitory concentration: 5000 nM
Estimate against measurement, compound 4: 20-fold (1.30 log units) above; low and high end bracket the measured number.
By their numbers in this assay, from the lowest: compound 3; then compounds 4 and 1 (each within the scatter of the next); then compound 2.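

In this assay the swap to a group of 3 heavy atoms with a net charge of +1, on a saturated chain carbon bound to a saturated ring carbon, does not simply lose inhibition: it loses much against the tail of compound 3 (a 280-fold higher number from compound 3 to compound 4 (2.44 log units; beyond the scatter)) but gains much against the tail of compound 2 (a 100-fold lower number from compound 2 to compound 4 (2.00 log units; beyond the scatter)). Against the tail of compound 1 it makes no real difference (a 1.4-fold lower number from compound 1 to compound 4 (0.15 log units; within the scatter)), so among these compounds a long tail here can help, do nothing or harm, depending on the tail. Nothing given here explains this ranking.

Still open, on these data alone, is whether a methylthio group, of similar size but with no net charge, would match compound 4. Also open, as far as these compounds go, is whether a longer chain ending in aminooxy would improve on compound 3.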